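Trimethoxyphenyl in Place of Methylphenyl: an Expectation

The compounds below may be only part of what the source reports. "The series", "measured", "known", "first", "only" and "open" are said of these compounds alone.

Three compounds have been measured in a functional assay on MCF7 cells (Homo sapiens) for inhibition, read by MTT assay, with a stated time of 72 h; a lower number here means a stronger inhibitor, a higher number a weaker inhibitor:

compound 1 `Cc1ccc(Nc2nc(SCc3cn(Cc4ccccc4Cl)nn3)nc(-c3ccccc3)c2C#N)cc1` gives 9420 nM
compound 2 `Cc1ccc(Nc2nc(SCc3cn(Cc4ccccc4Cl)nn3)nc(-c3ccc(C(C)C)cc3)c2C#N)cc1` gives 12200 nM
compound 3 `Cc1ccc(Nc2nc(SCc3cn(Cc4ccccc4Cl)nn3)nc(-c3ccc(C)cc3)c2C#N)cc1` gives 30900 nM

Compound 3 stands at the highest of the three numbers in this assay; the nearest is compound 2 and the furthest compound 1, both separated from it by more than the scatter. Two steps lead into compound 3: a 3.3-fold higher number from compound 1 to compound 3 (0.52 log units; beyond the scatter) and a 2.5-fold higher number from compound 2 to compound 3 (0.40 log units; beyond the scatter). By contrast, a 1.3-fold higher number from compound 1 to compound 2 (0.11 log units; within the scatter).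

Compound 4 `COc1cc(-c2nc(SCc3cn(Cc4ccccc4Cl)nn3)nc(Nc3ccc(C)cc3)c2C#N)cc(OC)c1OC` differs from compound 3 at the same aromatic carbon of the shared core: 3,4,5-trimethoxyphenyl in place of 4-methylphenyl on an aromatic carbon. The measured steps bear on this step only loosely. Within the data shown here, each of them exchanges one small group at that position, whereas here the whole 4-methylphenyl gives way to a 3,4,5-trimethoxyphenyl carrying three hydrogen-bond acceptors, and no measured pair shows what methoxy groups do in this assay. Both steps into compound 3 raise the number, so a modest lowering from compound 3 to compound 4 is expected, with low confidence, and a result within the scatter would not surprise. Compound 4 is therefore expected to give about 15000 nM in this assay, within a range from 4000 nM to 50000 nM, which corresponds to an expected step of a 2.1-fold lower number from compound 3 to compound 4 (0.31 log units; beyond the scatter).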

Compound 4, half-maximal inhibitory concentration: 20600 nM
The estimate for compound 4 lay 1.4-fold (0.14 log units) below the measured number, and the stated range covers the measured number.
By their numbers in this assay, from the lowest: compounds 1, 2, 4 and 3 (each within the scatter of the next, the first and the last beyond it).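

At this aromatic carbon, ortho to a cyano group on the shared core, 3,4,5-trimethoxyphenyl brings in 3 hydrogen-bond acceptors and more heavy atoms than any earlier group, yet in this assay the exchange gives a 1.5-fold lower number from compound 3 to compound 4 (0.18 log units; within the scatter), and the comparison with the isopropyl-bearing ring gives a 1.7-fold higher number from compound 2 to compound 4 (0.23 log units; within the scatter). So the earlier compounds left the effect of methoxy groups unknown, and compound 4 now shows that this larger, oxygen-bearing ring can sit at this position without separating from the 4-methylphenyl or 4-isopropylphenyl compounds. Only the comparison with the unsubstituted phenyl goes beyond the scatter, with a 2.2-fold higher number from compound 1 to compound 4 (0.34 log units; beyond the scatter), and nothing available accounts for these numbers.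

On these data alone, what a phenyl ring carrying a single methoxy group, a dimethylamino group or a carboxylic acid would give at this carbon remains open, so the contribution of each methoxy group cannot be separated from the whole 3,4,5-trimethoxyphenyl. Also open, as far as these compounds go, is whether the same exchange would read alike if a morpholine stood in place of the (4-methylphenyl)amino group.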